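Adding a Third Methoxy to the Ketone Aryl Ring

The source may report more compounds than this note shows. Statements on the series, on what has been measured and on what is new or still open speak of the compounds shown alone.

Measured compounds:
compound 1 `COc1ccc(C(=O)/C=C/c2cc(-c3cc(OC)c(OC)c(OC)c3)n[nH]2)cc1OC` gives 5240 nM
compound 2 `COc1cc(-c2cc(/C=C/C(=O)c3ccc(F)c(F)c3)[nH]n2)cc(OC)c1OC` gives 8500 nM

Both numbers come from a functional assay on NCI-H23 cells (Homo sapiens) for inhibition, read by sulforhodamine B assay, with a stated time of 48 h; a higher number here means a weaker inhibitor of growth, a lower number a stronger inhibitor of growth. Compound 1 has the lower of the two numbers, but the separation between them, a 1.6-fold higher number from compound 1 to compound 2 (0.21 log units; within the scatter), lies within the scatter, so the two cannot be placed in order.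

Compound 3 `COc1cc(C(=O)/C=C/c2cc(-c3cc(OC)c(OC)c(OC)c3)n[nH]2)cc(OC)c1OC` differs from compound 1 by methoxy in place of hydrogen on an aromatic carbon. The aryl ring on the carbonyl thus carries three methoxy groups instead of two, matching the pattern already present on the other aryl ring of the shared core.

Within the data shown here, no measured step adds a methoxy group. Among the measured compounds shown here, the only available step, a 1.6-fold higher number from compound 1 to compound 2 (0.21 log units; within the scatter), also alters the ring on the carbonyl, and it stayed within the scatter. On that basis the step of a 1.2-fold lower number from compound 1 to compound 3 (0.07 log units; within the scatter) is expected to be small, with no clear direction beyond the scatter. Compound 3 is therefore estimated at 4500 nM, with a range from 1500 nM to 13000 nM.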

Compound 3, concentration for total growth inhibition: 9900 nM
The estimate for compound 3 lay 2.2-fold (0.34 log units) below the measured number; low and high end bracket the measured number.
By their numbers in this assay, from the lowest: compounds 1, 2 and 3 (each within the scatter of the next).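

Compound 3 gives the first single-change test of adding a methoxy group on this aryl ring, at a carbon ortho to a methoxy group, whereas the earlier step exchanged the ring's substituents. In this assay, this addition gives a change that stays within the scatter (a 1.9-fold higher number from compound 1 to compound 3 (0.28 log units; within the scatter)), so it leaves no readable difference in growth inhibition. Having three methoxy groups on this ring, matching the other aryl ring, therefore sets compound 3 neither above nor below compound 1. No measurement available here accounts for this result.

As far as these compounds go, it remains open whether a different group at this same carbon, such as an amine, a carboxylic acid or a longer ethoxy chain, would move the number beyond the scatter. The same question stands for such groups on the other aryl ring.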